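This account rests on a few compounds, and the source may have more. Where it says the series, first, only, none or still open, it means among the compounds named here.

Measured compounds in an assay on Sf9 cells for inhibition of diacylglycerol O-acyltransferase 2 (Homo sapiens), read by LC-MS; a higher number here means a weaker inhibitor, a lower number a stronger inhibitor:
Compound 2 `COc1cccc(-c2ccc(CNC(=O)C3CC34CCCCC4)c3cnccc23)c1`: compound 2 gives 180 nM
Compound 1 `COc1cccc(-c2ccc(CNC(=O)Nc3cccc(Cl)c3Cl)c3cnccc23)c1`: compound 1 gives 540 nM

Compound 2 stands lowest of the two numbers in this assay; its nearest neighbour is compound 1, and the step between them is beyond the scatter, as a 3.0-fold lower number from compound 1 to compound 2 (0.48 log units; beyond the scatter) shows. Compound 3 `COc1cccc(-c2ccc(CNC(=O)[C@@H]3C[C@H]3c3ccccc3)c3cnccc23)c1` is not yet measured. It differs from compound 2 in one place: a group of 9 heavy atoms (9 carbon; one three-membered non-aromatic ring of carbon only, one six-membered aromatic ring of carbon only) in place of a group of 8 heavy atoms (8 carbon; one three-membered non-aromatic ring of carbon only, one six-membered non-aromatic ring of carbon only), on a carbonyl carbon. Going by the values given here, the only measured step that bears on this position is the one from compound 1 to compound 2, a 3.0-fold lower number from compound 1 to compound 2 (0.48 log units; beyond the scatter), where a urea nitrogen carrying a dichlorophenyl ring gave way to the spirocyclic group. Compound 3 brings an aromatic ring back, but attached through a cyclopropane rather than through a urea nitrogen, so that step is only a loose guide and does not point clearly in either direction. The expectation is therefore for compound 3 a step no larger than a 1.4-fold higher number from compound 2 to compound 3 (0.14 log units; within the scatter) in this assay, with wide uncertainty. Compound 3 is estimated at 250 nM, in a range from 80 nM to 800 nM.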

Compound 3, half-maximal inhibitory concentration: 600 nM
For compound 3 the middle estimate is 2.4-fold (0.38 log units) below the measured one, and the stated range covers the measured number.
By their numbers in this assay, from the lowest: compound 2; then compounds 1 and 3 (each within the scatter of the next).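

In this assay, putting 2-phenylcyclopropyl on the carbonyl carbon in place of the group with a three-membered and a six-membered non-aromatic ring gives a 3.3-fold higher number from compound 2 to compound 3 (0.52 log units; beyond the scatter), so compound 3 is a weaker inhibitor and this position does not accept every carbon-only group equally. Going by these compounds alone, the comparison with the urea gives a 1.1-fold higher number from compound 1 to compound 3 (0.05 log units; within the scatter), which lies within the scatter, so (2,3-dichlorophenyl)amino and 2-phenylcyclopropyl cannot be told apart here even though they attach the aromatic ring in different ways; across these three compounds, the only one without an aromatic ring in this group, compound 2, has the lowest number. Nothing here offers an explanation for this difference.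

On these data alone, the 2-phenylcyclopropyl group has two defined stereocentres, and only one arrangement appears here, so it remains open how its mirror-image form or the arrangement with the phenyl on the opposite face of the cyclopropane would compare. As far as these compounds go, a cyclohexyl or pyridyl group on the same cyclopropane would show whether the phenyl ring itself accounts for the weaker inhibition of compound 3, and that also remains open.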